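The source may hold more compounds than are shown below. What is called first, only, known or untested is meant among the compounds shown, and "the series" means these compounds.

Going by the values given here, compound 2 `CCCCC#Cc1cn(C/C=C/CN2C(=O)c3ccccc3C2=O)c(=O)[nH]c1=O` carries a butyl group on a triple-bonded carbon of the shared core, with its double bond drawn E. In a functional assay on HeLa cells (Homo sapiens) for antiproliferative activity, read by MTT assay, with a stated time of 3 days (a lower number here means a stronger inhibitor, a higher number a weaker inhibitor), compound 2 gives 89000 nM, the higher of the two numbers measured so far; its nearest neighbour is compound 1 `CCCCC#Cc1cn(C/C=C\CN2C(=O)c3ccccc3C2=O)c(=O)[nH]c1=O`, which gives 33000 nM in this assay. Compound 3 `CCCCCc1ccc(C#Cc2cn(C/C=C\CN3C(=O)c4ccccc4C3=O)c(=O)[nH]c2=O)cc1` reaches only the limit of this assay, > 100000 nM, so no number is known for it. Compound 4 `CCCCCCCCC#Cc1cn(C/C=C/CN2C(=O)c3ccccc3C2=O)c(=O)[nH]c1=O` differs from compound 2 by butyl in place of hydrogen on a saturated chain carbon, four bonds along the chain from a triple-bonded carbon. Among the compounds with values here, no measured step matches this change exactly. The nearest is the change from compound 1 to compound 3, where a larger group on the triple-bonded carbon brought an at least 3.0-fold higher number from compound 1 to compound 3 (0.48 log units; beyond the scatter), while the change in drawn configuration gave a 2.7-fold higher number from compound 1 to compound 2 (0.43 log units; beyond the scatter). Because an at least 3.0-fold higher number from compound 1 to compound 3 (0.48 log units; beyond the scatter), a modest weakening or no step beyond the scatter is expected for compound 4, a 1.7-fold higher number from compound 2 to compound 4 (0.23 log units; within the scatter). Compound 4 is therefore estimated at 150000 nM, between 60000 nM and 400000 nM, with a real chance that only the limit is reported.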

Compound 4, half-maximal inhibitory concentration: > 100000 nM
Compound 4: no number, only a limit; the forecaster's own chance of this, stated with the estimate: 55%; the middle value is on the limit's open side.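

In this assay compound 4 gives > 100000 nM, which is a limit of the assay and not a number. Going by these compounds alone, this is the first look at lengthening the saturated chain with the double bond drawn E, and the added butyl, four bonds along the chain from a triple-bonded carbon, did not produce a stronger compound: an at least 1.1-fold higher number from compound 2 to compound 4 (0.05 log units; that floor lies within the scatter). That floor leaves open whether the change truly weakens the compound, and its full size cannot be read because the read-out ends at a limit: the limit of > 100000 nM in this assay, at which 2 of the 4 values shown sit.

As far as these compounds go, whether an amine or a carboxylic acid in place of the added butyl would give a lower number remains open. So does the effect of the same longer chain with the double bond drawn Z.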